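Swapping the aminophenyl arm for a thiophene ring

The source may hold more compounds than are shown below. What is called first, only, known or untested is meant among the compounds shown, and "the series" means these compounds.

Compound 1 `Cc1ncc([N+](=O)[O-])n1CCSc1nnc(-c2ccccc2N)o1` and compound 2 `Cc1ncc([N+](=O)[O-])n1CCSc1nnc(-c2ccccc2[N+](=O)[O-])o1` share one core and differ only in the group carried on the six-membered aromatic ring. In a functional assay on SGC-7901 cells (Homo sapiens) for cytotoxicity, read by MTT assay, with a stated time of 48 h (on this read-out higher numbers stand for weaker inhibition and lower numbers for stronger inhibition), compound 1 gives 35100 nM, and in this assay compound 2 gives 30000 nM. Of the two numbers recorded so far, compound 1 stands highest, but the step of a 1.2-fold lower number from compound 1 to compound 2 (0.07 log units; within the scatter) lies within the scatter, so the two compounds cannot be told apart. Compound 3 `Cc1ncc([N+](=O)[O-])n1CCSc1nnc(-c2cccs2)o1` has not yet been measured. It differs from compound 1 in one place: thiophen-2-yl in place of 2-aminophenyl on an aromatic carbon. For the measured compounds named here, the single measured step, a 1.2-fold lower number from compound 1 to compound 2 (0.07 log units; within the scatter), concerns the same six-membered ring but exchanges a group on it rather than the ring itself, so it bears on the new change only loosely; what it shows is that altering that part of the molecule left the number unchanged. With nothing in the data pointing in either direction, the step of a 1.0-fold lower number from compound 1 to compound 3 (0.00 log units; within the scatter) is expected to stay within the scatter. Compound 3 is therefore estimated at 35000 nM, with a range from 12000 nM to 100000 nM.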

Compound 3, half-maximal inhibitory concentration: 30800 nM
For compound 3 the middle estimate is 1.1-fold (0.06 log units) above the measured one, within the range that was stated.
By their numbers in this assay, from the lowest: compounds 2, 3 and 1 (each within the scatter of the next).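

The earlier pair only exchanged a group on the six-membered aromatic ring, whereas this change replaces the whole 2-aminophenyl arm with thiophen-2-yl on the same aromatic carbon, and in this assay the result is a 1.1-fold lower number from compound 1 to compound 3 (0.06 log units; within the scatter). The position therefore accepts a five-membered aromatic ring with 1 hetero atom in place of a six-membered aromatic ring of carbon only, with 5 heavy atoms instead of 7 and 0 hydrogen-bond donors instead of 1, and the read-out does not separate the two compounds. No measurement bears on why the number holds across this exchange, so the result stands without an explanation.

The compounds shown all carry an aromatic ring at this position, so it remains open whether an amine, a carboxylic acid or a longer alkyl chain placed directly on that aromatic carbon would give a step beyond the scatter. Also open, as far as these compounds go, is whether this position has any bearing on the number at all, or whether a change elsewhere in the shared core would be needed to move it.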